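Working notes: a stereocentre left open at a ring carbon

This account rests on a few compounds, and the source may have more. Where it says the series, first, only, none or still open, it means among the compounds named here.

- compound 1 (`CC1=C(c2cccc(O)c2)C(c2ccc(OC[C@H](C)N3CCCCC3)cc2)Oc2ccc(O)cc21`), value 0.1 nM
- compound 2 (`CC1=C(c2cccc(O)c2)[C@@H](c2ccc(OC[C@H](C)N3CC[C@@H](C)C3)cc2)Oc2ccc(O)cc21`), value 59 nM

In a functional assay on MCF7 cells (Homo sapiens) for antiproliferative activity, read by CellTiter-Glo, with a stated time of 5 days (on this read-out higher numbers stand for weaker inhibition and lower numbers for stronger inhibition), compound 2 has the higher of the two numbers, beyond the scatter, and so the weaker inhibition. Going by the values given here, compound 1 is its only measured neighbour.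

Compound 3 (`CC1=C(c2cccc(O)c2)C(c2ccc(OC[C@H](C)N3CC[C@@H](C)C3)cc2)Oc2ccc(O)cc21`) has the same atoms and bonds as compound 2 (the two compounds have the same atoms and bonds; at least one stereo element is drawn with a configuration in one of them and without one in the other: 1 of 3 stereo elements differ; a stereocentre at a saturated ring carbon is drawn R in compound 2 and without a configuration in compound 3). A stereocentre at a saturated ring carbon is drawn R in compound 2 and without a configuration in compound 3.

Among the compounds with values here, no measured pair shows this change on its own, so the expectation rests on thin ground. Compound 1, also drawn without a configuration at that carbon, gives a far lower number (0.1 nM). On that single comparison, a large step towards stronger inhibition is expected in this assay, well beyond the scatter, although compound 3 could still stay close to compound 2 if the open drawing only reflects an unassigned centre. The expected change is a 150-fold lower number from compound 2 to compound 3 (2.17 log units; beyond the scatter) (an estimate). For compound 3 the estimated value is 0.4 nM (expected range 0.05 nM to 8 nM).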

Compound 3, half-maximal inhibitory concentration: 0.2 nM
Compound 3: middle estimate off by 2.0-fold (0.30 log units), on the high side, and the stated range covers the measured number.
By their numbers in this assay, from the lowest: compounds 1 and 3 (each within the scatter of the next); then compound 2.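

In this assay, the stereocentre at a saturated ring carbon proves a sensitive place, with a 300-fold lower number from compound 2 to compound 3 (2.47 log units; beyond the scatter), and the structures offer only one source for this gap: the fact that one of compounds 2 and 3 is drawn with a defined configuration and the other without, at the place where they differ

The ring on the saturated chain carbon bound to two saturated chain carbons behaves differently. With the stereocentre left open, a group with one five-membered non-aromatic ring in place of one with a six-membered non-aromatic ring gives a 2.0-fold higher number from compound 1 to compound 3 (0.30 log units; within the scatter). The five-membered ring alone therefore does not set compound 2 apart, since compound 3 carries the same ring and gives 0.2 nM, whereas compound 2 gives 59 nM.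

The compounds shown leave open whether the drawing of compound 3 stands for a mixture at that ring carbon or for a single form, and how the opposite defined configuration would read. Also open, on these data alone, is how a morpholine or a dimethylamino group on the same saturated chain carbon would read in this assay.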